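The compounds below may be only part of what the source reports. "The series", "measured", "known", "first", "only" and "open" are said of these compounds alone.

In a functional assay on A549 cells (Homo sapiens) for antiproliferative activity, read by MTT assay, with a stated time of 48 h (a lower number here means a stronger inhibitor, a higher number a weaker inhibitor), compound 2 `N#Cc1ncn(Cc2ccc(F)cc2)c1/N=C/c1ccc([N+](=O)[O-])cc1` gives 2020 nM and compound 3 `COc1ccc(/C=N/c2c(C#N)ncn2Cc2ccc(F)cc2)cc1` gives 4620 nM, so compound 3 holds the higher of the two actual numbers and is the weaker of this pair. Compound 1 `COc1ccc(/C=N/c2c(C#N)ncn2-c2ccc(F)cc2)cc1O`, which also carries a hydroxy group, gives > 25000 nM, and this is a limit of the assay and not a number.

Compound 4 `COc1ccc(/C=N/c2c(C#N)ncn2Cc2ccc(F)cc2)cc1O` comes from compound 3 by one change: hydroxy in place of hydrogen on an aromatic carbon, with hydroxy in place of hydrogen on an aromatic carbon, ortho to a methoxy group. Among the measured compounds shown here, no measured step adds this group directly. The closest guide is a 2.3-fold higher number from compound 2 to compound 3 (0.36 log units; beyond the scatter), a modest shift for methoxy in place of nitro. Compound 1 differs from compound 4 elsewhere too, so it offers only a mild warning towards a weaker result.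

A small move towards a higher number is therefore expected, and the estimated step is a 1.2-fold higher number from compound 3 to compound 4 (0.08 log units; within the scatter). For compound 4 the estimated value is 5500 nM, with an expected range of 1800 nM to 17000 nM.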

Compound 4, half-maximal inhibitory concentration: 1320 nM
Compound 4: middle estimate off by 4.2-fold (0.62 log units), on the high side; the whole stated range lies above it.
By their numbers in this assay, from the lowest: compounds 4 and 2 (each within the scatter of the next); then compound 3. At a limit, above all of these: compound 1.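

In this assay, among the compounds shown here, putting a hydroxy on this aromatic carbon, ortho to a methoxy group, gives a 3.5-fold lower number from compound 3 to compound 4 (0.54 log units; beyond the scatter), so this position tolerates the added group and even gains from it, which no earlier pair could show. With the hydroxy and methoxy kept, 4-fluorobenzyl in place of 4-fluorophenyl on the aromatic nitrogen gives an at least 18-fold lower number from compound 1 to compound 4 (1.27 log units; beyond the scatter), so the hydroxy alone does not bring the weak result of compound 1. The value of compound 1 is a limit and not a number, so that step gives only a minimum size: the limit of > 25000 nM in this assay, at which 1 of the 4 values shown sits.

Going by these compounds, it remains open whether the gain is specific to hydroxy, which an amine or a fluorine on the same carbon would help to settle. It is also unclear how a longer chain in place of 4-fluorobenzyl on the nitrogen would fare.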